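The source may report more compounds than this note shows. Statements on the series, on what has been measured and on what is new or still open speak of the compounds shown alone.

Going by the values given here, compound 3 `Cc1ccc(C(=O)NN(C(=O)c2ccccc2Cl)C(C)(C)C)c(C)c1` is one of three compounds measured in an assay on cells for agonist activity at ecdysone receptor (Bombyx mori), read by a luciferase reporter, with a stated time of 24 h (a higher number here means that more compound is needed for the effect, a lower number that less compound is needed), that share a core in which two acyl groups sit on a hydrazine bearing a tert-butyl group. In this assay compound 3 gives 162 nM, the second highest of the three numbers. Compound 1 `CC(C)(C)N(NC(=O)c1cccc(Br)c1)C(=O)c1ccccc1Cl` gives 191 nM, and a 1.2-fold lower number from compound 1 to compound 3 (0.07 log units; within the scatter), so the two values cannot be told apart. Compound 2 `COc1cccc(C(=O)NN(C(=O)c2ccccc2Cl)C(C)(C)C)c1` gives 52.5 nM, and a 3.1-fold higher number from compound 2 to compound 3 (0.49 log units; beyond the scatter), while a 3.6-fold lower number from compound 1 to compound 2 (0.56 log units; beyond the scatter).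

Compound 4 `CCCCCCC(=O)NN(C(=O)c1ccccc1Cl)C(C)(C)C` differs from compound 3 in a single place: hexyl in place of 2,4-dimethylphenyl on a carbonyl carbon. Among the compounds with values here, both measured steps that touch this carbonyl carbon exchanged one aromatic ring for another, and neither removed the ring altogether, so the hexyl chain has no direct precedent among the compounds at hand. Those steps were modest at most. Replacing the ring by a chain is a larger departure than either of them, and it is expected to raise the number in this assay by more than either measured step, that is, to make compound 4 less potent than compound 3. The step from compound 3 to compound 4 is expected to be a 9.3-fold higher number from compound 3 to compound 4 (0.97 log units; beyond the scatter), and compound 4 is estimated at 1500 nM, within a range from 300 nM to 8000 nM.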

Compound 4, half-maximal effective concentration: 741 nM
The estimate for compound 4 lay 2.0-fold (0.31 log units) above the measured number; low and high end bracket the measured number.
By their numbers in this assay, from the lowest: compound 2; then compounds 3 and 1 (each within the scatter of the next); then compound 4.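

Going by these compounds alone, at this carbonyl carbon the earlier compounds only exchanged one aromatic ring for another, and compound 4 now shows that in this assay a number can still be read with no ring there at all: compound 4, which carries hexyl, gives 741 nM and stays within the range spanned by modest steps from two of the ring compounds. All three ring compounds have lower numbers than the chain compound, with a 4.6-fold higher number from compound 3 to compound 4 (0.66 log units; beyond the scatter) and a 3.9-fold higher number from compound 1 to compound 4 (0.59 log units; beyond the scatter) both modest, and with a 14-fold higher number from compound 2 to compound 4 (1.15 log units; beyond the scatter) large, the largest step seen at this position. The size of the change therefore depends on which ring the chain replaces, and it is large only where hexyl takes the place of 3-methoxyphenyl.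

Going by these compounds, whether a longer chain, a shorter one such as butyl, a chain ending in an amine or a saturated cyclohexyl ring would bring the number back towards those of the ring compounds remains open. No measurement at hand accounts for the size of these steps.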